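The compounds below may be only part of what the source reports. "The series", "measured", "known", "first", "only" and "open" are said of these compounds alone.

Compounds measured in an assay on isolated protein for inhibition of Nicotinamide phosphoribosyltransferase (Homo sapiens), read by mass spectrometry, with stated times of 15 min and 30 min; a lower number here means a stronger inhibitor, a higher number a weaker inhibitor:
- compound 1, `COc1cccc(S(=O)(=O)c2ccc(CN/C(=N\C#N)Nc3ccncc3)cc2)c1`: 1.9 nM
- compound 2, `N#C/N=C(\NCc1ccc(S(=O)(=O)C2CCCCC2)cc1)Nc1ccncc1`: 5.4 nM
- compound 3, `N#C/N=C(\NCc1ccc(S(=O)(=O)N2CC3CCC(C2)O3)cc1)Nc1cccnc1`: 4.4 nM

The three compounds share one core and differ at the group on the sulfonyl sulfur. Compound 2 carries the highest of the three numbers in this assay, but compound 3 sits within the usual scatter of it, so no order between those two can be read. Among the measured compounds shown here, compound 1 is set apart: the only one-place step among the measured compounds, a 2.8-fold higher number from compound 1 to compound 2 (0.45 log units; beyond the scatter), is a modest rise that exceeds the scatter.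

The account now moves from compound 2 to compound 4, `N#C/N=C(\NCc1ccc(S(=O)(=O)c2cccc(C(F)(F)F)c2)cc1)Nc1ccncc1`. The change is 3-(trifluoromethyl)phenyl in place of cyclohexyl on a sulfonyl sulfur.

For the measured compounds named here, one measured step bears on this change: a 2.8-fold higher number from compound 1 to compound 2 (0.45 log units; beyond the scatter), in which a cyclohexyl replaced an aromatic group on the same sulfonyl sulfur and the number went up. Compound 4 runs that exchange the other way, putting an aromatic group back in place of the cyclohexyl, though the 3-(trifluoromethyl)phenyl is not the 3-methoxyphenyl of compound 1. A modest fall in this assay is therefore expected, of about the size seen between compound 1 and compound 2, as a 1.9-fold lower number from compound 2 to compound 4 (0.29 log units; within the scatter). For compound 4 the expected value is 2.8 nM, in the range 1.2 nM to 7 nM.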

Compound 4, half-maximal inhibitory concentration: 2.4 nM
Compound 4: the middle estimate sits 1.2-fold (0.07 log units) above what was measured; the range from low to high includes it.
By their numbers in this assay, from the lowest: compounds 1, 4, 3 and 2 (each within the scatter of the next, the first and the last beyond it).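

In this assay, the exchange between cyclohexyl and an aromatic group on the sulfonyl sulfur now has a second instance: a 2.3-fold lower number from compound 2 to compound 4 (0.35 log units; beyond the scatter) stands alongside the earlier 2.8-fold higher number from compound 1 to compound 2 (0.45 log units; beyond the scatter), so in both pairs the compound with the aromatic group carries the lower number, whether that group is 3-(trifluoromethyl)phenyl or 3-methoxyphenyl. The new comparison between the two aromatic groups, trifluoromethyl in place of methoxy on an aromatic carbon, gives a 1.3-fold higher number from compound 1 to compound 4 (0.10 log units; within the scatter), which lies within the scatter, so no order can be read between these two compounds and this exchange on the ring shows no measurable effect in this assay. Nothing available explains either step.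

Going by these compounds, how a plain phenyl, or a phenyl carrying an amine or a carboxylic acid, would stand against compound 1 and compound 4 remains open. Compound 3 differs from the other compounds in more than one place, so the effect of its group on the sulfonyl sulfur cannot be isolated in a single step.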